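Pyridin-4-yl in Place of 2-Chlorophenyl

The compounds below may be only part of what the source reports. "The series", "measured", "known", "first", "only" and "open" are said of these compounds alone.

The account starts from compound 2 `Cc1cc(NC(=O)Cn2cc(-c3ccccc3Cl)nn2)no1`. In a functional assay on BMDM cells (Mus musculus, strain C57BL/6) for inhibition, with a stated time of 2 days (a lower number here means a stronger inhibitor, a higher number a weaker inhibitor), compound 2 gives only a limit, > 30000 nM, and not a number. Compound 2 therefore sits at the limit of > 30000 nM in this assay, at which 1 of the 2 values shown sits. Compound 1 `Cc1csc(NC(=O)Cn2cc(-c3ccncc3)nn2)n1` carries a pyridin-4-yl group and differs from compound 2 in another part of the molecule as well; in this assay compound 1 gives 100 nM. Compound 3 `Cc1cc(NC(=O)Cn2cc(-c3ccncc3)nn2)no1` has not yet been measured. The change from compound 2 to compound 3 is pyridin-4-yl in place of 2-chlorophenyl on an aromatic carbon. Among the measured compounds shown here, no measured pair isolates this single change, so the size of the step rests on expectation alone. Because compound 1, which also carries pyridin-4-yl, reaches 100 nM, a clear gain in potency, well beyond the scatter, is expected. Compound 3 is expected to give 1000 nM, with a range from 150 nM to 20000 nM. The expected step is an at least 30-fold lower number from compound 2 to compound 3 (1.47 log units; beyond the scatter).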

Compound 3, half-maximal inhibitory concentration: 430 nM
Compound 3: middle estimate off by 2.3-fold (0.37 log units), on the high side; measured number inside the range.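

In this assay, a pair of compounds now isolates pyridin-4-yl in place of 2-chlorophenyl on an aromatic carbon, and the result is an at least 69-fold lower number from compound 2 to compound 3 (1.84 log units; beyond the scatter) for this single change. That step is open-ended, because compound 2 gives a limit and not a number: the limit of > 30000 nM in this assay, at which 1 of the 3 values shown sits. The group on the amide-type nitrogen also matters with pyridin-4-yl in place, since 5-methyl-1,2-oxazol-3-yl in place of 4-methyl-1,3-thiazol-2-yl gives a 4.3-fold higher number from compound 1 to compound 3 (0.63 log units; beyond the scatter) on the otherwise shared structure.

The compounds shown leave open whether a pyridin-3-yl group, with its ring nitrogen elsewhere, would serve as well as pyridin-4-yl. They also do not tell how an amine or a methoxy group on the pyridin-4-yl ring would change the number.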